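A Silyl-Bearing Side Chain on an Inactive Triol Scaffold

The source may hold more compounds than are shown below. What is called first, only, known or untested is meant among the compounds shown, and "the series" means these compounds.

The series was examined in a functional assay on HepG2 cells (Homo sapiens) for antiproliferative activity, read by MTT assay, with a stated time of 72 h; on this read-out lower numbers stand for stronger inhibition and higher numbers for weaker inhibition. Compound 1 `COc1cc(CC(O)(COCc2ccccc2)COCc2ccccc2)nc(OC)n1` reached only the limit of the assay, giving > 100000 nM. Compound 2 `C[Si](C)(C)CCOCn1c(CC(O)(COCc2ccccc2)COCc2ccccc2)cc(=O)[nH]c1=O` likewise sits at the limit, with > 100000 nM. Compound 3 `COCn1c(CC(O)(CO)CO)cc(=O)[nH]c1=O`, the compound from which the present step departs, also returns only a limit, namely > 100000 nM; it therefore stands nowhere within the measured range, but at the same limit as the two others, as the limit of > 100000 nM in this assay, at which 3 of the 3 values shown sit, records.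

Compound 4 `C[Si](C)(C)CCOCn1c(CC(O)(CO)CO)cc(=O)[nH]c1=O` has not yet been measured in this assay. It differs from compound 3 by a group of 5 heavy atoms (4 carbon, 1 silicon; no ring) in place of a hydrogen atom, on a saturated chain carbon bound to an oxygen on a saturated carbon. The nearest point of comparison is compound 2, which already carries this same group, and nonetheless gives only a limit, > 100000 nM.

Among the compounds with values here, no step between measured compounds is available, and every value shown is a limit. Against that background no change beyond the scatter is expected in this assay, and compound 4 is estimated to remain at the limit, with an expected step that the limit leaves unreadable from compound 3 to compound 4. The estimate for compound 4 is 150000 nM, with a range from 60000 nM to 500000 nM, and the most likely outcome is that this assay again reports only a limit.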

Compound 4, half-maximal inhibitory concentration: > 100000 nM
Compound 4 gave a limit, no number (the forecaster's own chance of this, stated with the estimate: 88%); the middle value lies beyond the limit too.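

Within the data shown here, compound 3 and compound 4 both return only a limit in this assay, so no step between them can be read: the limit of > 100000 nM in this assay, at which 4 of the 4 values shown sit.

The compounds shown leave open whether any member of this series reaches a measurable value, and what the group carried by compound 4 does where a value can be read.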